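This account rests on a few compounds, and the source may have more. Where it says the series, first, only, none or still open, it means among the compounds named here.

Compound 1 `COc1cccc(CNCCCNc2ccnc3cc(CC(C)C)ccc23)c1O`: 23 10^-6 cm/s
Compound 2 `COc1ccccc1Oc1ccc2c(NCCCNCc3cccc(OC)c3O)ccnc2c1`: 317 10^-6 cm/s

Of the compounds shown here, two have been measured in an ADME assay for permeability, using PAMPA, with a stated time of 30 min, at pH 7.4; on this read-out higher numbers stand for higher permeability and lower numbers for lower permeability. Compound 1 gives 23 10^-6 cm/s, and compound 2 gives 317 10^-6 cm/s, so compound 2 stands highest of the two numbers. Among the measured compounds shown here, the one step between them, a 14-fold higher number from compound 1 to compound 2 (1.14 log units; beyond the scatter), follows the exchange of 2-methoxyphenoxy for isobutyl on an aromatic carbon.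

Compound 3 `COc1cccc(CNCCCNc2ccnc3cc(Oc4ccc(Cl)cc4)ccc23)c1O` keeps the core of compound 2 and differs only in the aryl ether: 4-chlorophenyl in place of 2-methoxyphenyl on an oxygen on an aromatic ring. For the measured compounds named here, no measured step follows a change of this kind; the step from compound 1 to compound 2 concerns a different replacement and bears on it only loosely, in that both compound 2 and compound 3 carry a phenoxy group at this place. Compound 3 is therefore expected to stay near compound 2, with a step of a 1.1-fold lower number from compound 2 to compound 3 (0.05 log units; within the scatter), not beyond the scatter. The estimate for compound 3 is 280 10^-6 cm/s, within a range from 110 10^-6 cm/s to 600 10^-6 cm/s.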

Compound 3, apparent permeability: 317 10^-6 cm/s
Estimate against measurement, compound 3: 1.1-fold (0.05 log units) below, within the range that was stated.
By their numbers in this assay, from the lowest: compound 1; then compounds 2 and 3 (each within the scatter of the next).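

In this assay, 4-chlorophenyl in place of 2-methoxyphenyl on an oxygen on an aromatic ring gives no change at the digits printed from compound 2 to compound 3 (within the scatter), so the high number at this position does not rest on the 2-methoxyphenyl group alone. With 4-chlorophenoxy in place of isobutyl on an aromatic carbon the read-out shows a 14-fold higher number from compound 1 to compound 3 (1.14 log units; beyond the scatter), and two different phenoxy groups now stand well above isobutyl at this place. No measurement at hand bears on why the two aryl ethers read alike.

Open, from the compounds shown here alone, is how an amine or a carboxylic acid on this aromatic carbon would read, and whether a plain phenyl on the oxygen would stay with compound 2 and compound 3. Also open, going by these compounds, is whether a longer chain in place of isobutyl would close the gap to the phenoxy compounds.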